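The source may hold more compounds than are shown below. What is called first, only, known or untested is meant among the compounds shown, and "the series" means these compounds.

Compound 3 `Cc1nn(-c2nc(-c3ccc(Cl)c(Cl)c3)c(SC(C)C)s2)c(C(=O)O)c1-c1ccncc1` carries a pyridin-4-yl group on the shared core. In a functional assay on BJAB cells (Homo sapiens) for antiproliferative activity, with a stated time of 4 days (a higher number here means that more compound is needed for the effect, a lower number that less compound is needed), compound 3 gives 5900 nM. Among the three measured compounds this is the second highest number: compound 1 `Cc1cc(C)cc(-c2c(C)nn(-c3nc(-c4ccc(Cl)c(Cl)c4)c(SC(C)C)s3)c2C(=O)O)c1`, with 3,5-dimethylphenyl at the same carbon, gives 2700 nM, and compound 2 `COc1cncc(-c2c(C)nn(-c3nc(-c4ccc(Cl)c(Cl)c4)c(SC(C)C)s3)c2C(=O)O)c1`, with 5-methoxypyridin-3-yl there, gives 21000 nM. Compound 4 `Cc1nn(-c2nc(-c3ccc(Cl)c(Cl)c3)c(SC(C)C)s2)c(C(=O)O)c1-c1ccc(C(F)(F)F)cc1` is the untested one, and its change from compound 3 is 4-(trifluoromethyl)phenyl in place of pyridin-4-yl on an aromatic carbon. Among the compounds with values here, two measured steps bear on it. The step of a 2.2-fold higher number from compound 1 to compound 3 (0.34 log units; beyond the scatter) shows that moving from a carbon-only ring to the pyridin-4-yl ring went with a higher number, while the step of a 3.6-fold lower number from compound 2 to compound 3 (0.55 log units; beyond the scatter) shows that pyridin-4-yl gave a lower number than the other nitrogen-containing ring. Compound 4 returns to a carbon-only ring, though with a substituent not yet tested in this series. For compound 4 the step is therefore expected to be a modest lowering, a 2.0-fold lower number from compound 3 to compound 4 (0.29 log units; within the scatter), with the direction uncertain. Compound 4 is estimated at 3000 nM, within 1000 nM to 9000 nM.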

Compound 4, half-maximal effective concentration: 3500 nM
Compound 4: middle estimate off by 1.2-fold (0.07 log units), on the low side, within the range that was stated.
By their numbers in this assay, from the lowest: compounds 1, 4 and 3 (each within the scatter of the next, the first and the last beyond it); then compound 2.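

In this assay, the 4-(trifluoromethyl)phenyl group of compound 4 cannot be told apart from the pyridin-4-yl group, with a 1.7-fold lower number from compound 3 to compound 4 (0.23 log units; within the scatter), or from the 3,5-dimethylphenyl group, with a 1.3-fold higher number from compound 1 to compound 4 (0.11 log units; within the scatter), both within the scatter, so this position accepts a ring with a trifluoromethyl substituent and more heavy atoms without a clear change in the number. The one clear separation is from the 5-methoxypyridin-3-yl group, with a 6.0-fold lower number from compound 2 to compound 4 (0.78 log units; beyond the scatter), which means that a carbon-only ring and a ring with nitrogen do not fall into two distinct groups here, since compound 3 stays within the scatter of compound 4. Nothing available explains why these rings compare as they do.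

From the compounds shown here alone, it remains open how an amine or a hydroxyl group on this ring would behave. A saturated ring such as piperidine, or a longer alkyl chain in place of the ring, is equally untested among the compounds shown.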